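The compounds below may be only part of what the source reports. "The series", "measured", "known", "first", "only" and "open" are said of these compounds alone.

Compound 1 `O=C1/C(=C/c2ccccc2Cl)Cc2ccccc21` was tested in a functional assay on L1210 cells (Mus musculus) for inhibition (a higher number here means a weaker inhibitor, a lower number a stronger inhibitor), and gave 152000 nM. Of the two plain numbers in this set, that of compound 1 is the higher one, so it is the weaker inhibitor of the two. Compound 2 `O=C1/C(=C/c2ccccc2[N+](=O)[O-])CCc2ccccc21` gives 10800 nM in this assay, a lower number. Compound 3 `O=C1/C(=C/c2ccc(Cl)cc2Cl)Cc2ccccc21` reached only the limit of the measurement, > 500000 nM, and no number is known for it. Going by the values given here, the one measured step that starts from compound 1 is an at least 3.2-fold higher number from compound 1 to compound 3 (0.51 log units; beyond the scatter); the size of this step rests on (the limit of > 500000 nM in this assay, at which 1 of the 3 values shown sits).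

Compound 4 `O=C1/C(=C/c2ccccc2Br)Cc2ccccc21` has not yet been measured. It differs from compound 1 by bromo in place of chloro on an aromatic carbon. Among the compounds with values here, no measured pair here swaps one halogen for another; the step from compound 1 to compound 3 adds a second chloro rather than exchanging one, so it is of a different kind and gives little guide. Since bromo simply takes the place of chloro, one atom for one atom, the change is expected to move the number in this assay little, if at all beyond the scatter. The expected value for compound 4 is therefore 130000 nM, with a range from 45000 nM to 400000 nM. That would be an expected step of a 1.2-fold lower number from compound 1 to compound 4 (0.07 log units; within the scatter).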

Compound 4, half-maximal inhibitory concentration: 64200 nM
For compound 4 the middle estimate is 2.0-fold (0.31 log units) above the measured one, and the stated range covers the measured number.
By their numbers in this assay, from the lowest: compound 2; then compound 4; then compound 1. At a limit, above all of these: compound 3.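

Exchanging one halogen for another at this place, ortho to a large group, with one heavy atom leaving and one entering and no hydrogen-bond donor, acceptor or charge involved, gives a 2.4-fold lower number from compound 1 to compound 4 (0.37 log units; beyond the scatter). So in this assay the choice of halogen at this place does register: of this pair, compound 4, with bromo, is the stronger inhibitor, though the step is only modest. The earlier step that added a second chloro ended at a limit of the assay, whereas this step joins two plain numbers, so its size can be read directly, but nothing measured here accounts for the difference between chloro and bromo.

On these data alone, whether the trend seen in this single pair extends to iodo, or reverses with fluoro, remains open, as does the behaviour of quite different groups at this place, such as a methoxy group, an amine or a carboxylic acid. As far as these compounds go, compound 2 differs from compound 1 in more than one place, so its lower number cannot be set beside this step, and what the nitro group alone contributes also remains unknown.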